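Thiophen-3-yl in place of piperidin-1-yl on a carbonyl carbon

The source may report more compounds than this note shows. Statements on the series, on what has been measured and on what is new or still open speak of the compounds shown alone.

Three compounds share one core and differ only in the ring on a carbonyl carbon, and all were tested in a functional assay on BXPC-3 cells (Homo sapiens) for antiproliferative activity, read by sulforhodamine B assay, with a stated time of 72 h (on this read-out higher numbers stand for weaker inhibition and lower numbers for stronger inhibition), for their effect on cell growth. Compound 1 `CC(C)(C)c1[nH]cnc1/C=c1\[nH]c(=O)/c(=C/c2cccc(C(=O)N3CCC3)c2)[nH]c1=O` gives > 500 nM as its reading, which is a limit and not a number. Compound 2 `CC(C)(C)c1[nH]cnc1/C=c1\[nH]c(=O)/c(=C/c2cccc(C(=O)N3CCCC3)c2)[nH]c1=O` gives 325 nM and compound 3 `CC(C)(C)c1[nH]cnc1/C=c1\[nH]c(=O)/c(=C/c2cccc(C(=O)N3CCCCC3)c2)[nH]c1=O` gives 100 nM as the lowest number of the set, making it the most potent of the three.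

The change to compound 4 `CC(C)(C)c1[nH]cnc1/C=c1\[nH]c(=O)/c(=C/c2cccc(C(=O)c3ccsc3)c2)[nH]c1=O` is thiophen-3-yl in place of piperidin-1-yl on a carbonyl carbon and puts thiophen-3-yl in place of piperidin-1-yl on a carbonyl carbon. The measured steps at this same carbon are a 3.3-fold lower number from compound 2 to compound 3 (0.51 log units; beyond the scatter) and an at least 5.0-fold lower number from compound 1 to compound 3 (0.69 log units; beyond the scatter) as well as an at least 1.5-fold lower number from compound 1 to compound 2 (0.18 log units; that floor lies within the scatter) for the remaining pair. Each of them swaps one non-aromatic ring for another, so none tests an aromatic ring there. For the measured compounds named here, they show only that the number responds to changes at this place, by modest amounts. A modest step is therefore expected, tentatively toward a lower number, with the direction far from certain. The expected change is a 2.0-fold lower number from compound 3 to compound 4 (0.30 log units; within the scatter) in this tentative reading. The estimate for compound 4 is 50 nM (expected range 8 nM to 300 nM).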

Compound 4, half-maximal inhibitory concentration: 1.56 nM
Beside the measured number, compound 4's estimate is 32-fold (1.51 log units) above it; the whole stated range lies above it.
By their numbers in this assay, from the lowest: compound 4; then compound 3; then compound 2. At a limit, above all of these: compound 1.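

Until now, only non-aromatic rings joined through nitrogen had been compared on this carbonyl carbon, and the measured steps among them were modest; the aromatic thiophen-3-yl shows that this position can give a far larger gain in this assay (a 64-fold lower number from compound 3 to compound 4 (1.81 log units; beyond the scatter)). Ring size alone does not describe the result: compound 4 carries a five-membered ring, as compound 2 does with its pyrrolidin-1-yl, yet the two lie far apart (a 210-fold lower number from compound 2 to compound 4 (2.32 log units; beyond the scatter)), so the drop in number from the five-membered ring of compound 2 to the six-membered ring of compound 3 does not extend to compound 4. The step from compound 1 is also large (an at least 320-fold lower number from compound 1 to compound 4 (2.50 log units; beyond the scatter)), but it is only a floor, resting on a limit and not on a number: the limit of > 500 nM in this assay, at which 1 of the 4 values shown sits.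

Two things change together in compound 4, since the ring becomes aromatic and joins the carbonyl through carbon instead of nitrogen, and the compounds shown cannot separate these two changes or say why the number falls. A cyclohexyl ring on the same carbonyl carbon would test joining through carbon without an aromatic ring, while a phenyl ring would test whether the sulfur of the thiophene matters.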